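Extending the benzyl group of compound 3 toward tighter binding

This account rests on a few compounds, and the source may have more. Where it says the series, first, only, none or still open, it means among the compounds named here.

Of the compounds shown here, three have been measured in an assay on isolated protein for displacement of a labelled ligand from Apoptosis regulator Bcl-2 (Homo sapiens), read by fluorescence polarization; a higher number here means a weaker inhibitor, a lower number a stronger inhibitor. Compound 1, `COC1(Cc2ccccc2Br)CCN(c2ccc(C(=O)NS(=O)(=O)c3ccc(N[C@H](CCN(C)C)CSc4ccccc4)c([N+](=O)[O-])c3)cc2)CC1`, gives 1.5 nM, and compound 2, `COc1ccccc1C=C1CCN(c2ccc(C(=O)NS(=O)(=O)c3ccc(N[C@H](CCN(C)C)CSc4ccccc4)c([N+](=O)[O-])c3)cc2)CC1`, gives 2 nM. Compound 3, `CN(C)CC[C@H](CSc1ccccc1)Nc1ccc(S(=O)(=O)NC(=O)c2ccc(N3CCN(Cc4ccccc4)CC3)cc2)cc1[N+](=O)[O-]`, gives 39.8 nM, the highest number of the three; the gap to compound 2 and the larger gap to compound 1 both lie beyond the usual scatter, so compound 3 is the weakest inhibitor shown.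

Compound 4, `CN(C)CC[C@H](CSc1ccccc1)Nc1ccc(S(=O)(=O)NC(=O)c2ccc(N3CCN(Cc4ccccc4-c4ccc(S(C)(=O)=O)cc4)CC3)cc2)cc1[N+](=O)[O-]`, is built from compound 3 by a single change: 4-(methylsulfonyl)phenyl in place of hydrogen on an aromatic carbon. Among the measured compounds shown here, no step between two measured compounds matches this change, so there is no direct precedent. What the numbers do show is that compound 1 and compound 2, which carry bulkier groups on the ring at this end of the shared core, give lower numbers than compound 3.

From that, compound 4 is expected to give a lower number than compound 3, with the step from a 5.0-fold lower number from compound 3 to compound 4 (0.70 log units; beyond the scatter) estimated as clearly beyond the scatter. For compound 4 the estimate in this assay is 8 nM, with a likely range from 2 nM to 30 nM.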

Compound 4, inhibition constant: < 1 nM
Compound 4 ended at the assay's limit; the forecaster's own chance of this, stated with the estimate: 0%; middle value at least 8.0-fold (0.90 log units) from the limit.
By their numbers in this assay, from the lowest: compounds 1 and 2 (each within the scatter of the next); then compound 3. At a limit, below all of these: compound 4.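

This is the only pair shown that differs in one place, and it shows that an aromatic carbon ortho to a large group accepts a 4-(methylsulfonyl)phenyl group in place of hydrogen with no loss of binding: in this assay the change gives an at least 39-fold lower number from compound 3 to compound 4 (1.59 log units; beyond the scatter). The new aromatic ring and the methylsulfonyl group enter together, and this single step does not separate what each contributes. Compound 4 reads < 1 nM, which is a limit of the assay and not a number, so the step gives only a minimum size: the limit of < 1 nM in this assay, at which 1 of the 4 values shown sits.

On these data alone, whether a plain phenyl group would give a step of similar size stays open, as does the effect of a carboxylic acid or an amine in place of the methylsulfonyl group. The compounds shown also do not tell how the same 4-(methylsulfonyl)phenyl group would read on another carbon of this ring.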